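The source may report more compounds than this note shows. Statements on the series, on what has been measured and on what is new or still open speak of the compounds shown alone.

Compound 3 `C#CCN1CCN(CC(=O)N2CCN(c3ccc(C(=O)c4cc5ccc(N(CC)CC)cc5o4)cc3)CC2)CC1` gives the highest number of the three measured in a functional assay on HCT-116 cells (Homo sapiens) for cytotoxicity, read by MTT assay, with a stated time of 48 h (a higher number here means a weaker inhibitor, a lower number a stronger inhibitor), namely 17700 nM; compound 1 `CCN(CC)c1ccc2cc(C(=O)c3ccc(N4CCN(C(=O)CN5CCN(C(=O)/C=C/c6ccccc6)CC5)CC4)cc3)oc2c1` gives 6810 nM and compound 2 `CCN(CC)c1ccc2cc(C(=O)c3ccc(N4CCN(C(=O)CN5CCN(S(=O)(=O)c6ccc(OC(F)(F)F)cc6)CC5)CC4)cc3)oc2c1` gives 7680 nM. Compound 4 `CCN(CC)c1ccc2cc(C(=O)c3ccc(N4CCN(C(=O)CN5CCN(CC(C)=O)CC5)CC4)cc3)oc2c1` differs from compound 3 by acetyl in place of ethynyl on a saturated chain carbon bound to an amine nitrogen in a ring. Among the measured compounds shown here, only one measured step touches the same place: a 2.6-fold higher number from compound 1 to compound 3 (0.41 log units; beyond the scatter), an exchange that, in the opposite direction, likewise replaced a carbonyl-bearing group with propargyl. That step was modest, and the acetyl entering in compound 4 is smaller than the group that left in that step, so the expected step in this assay is small and, if anything, toward a lower number, with a 1.3-fold lower number from compound 3 to compound 4 (0.10 log units; within the scatter). Compound 4 is therefore estimated at 14000 nM, between 6000 nM and 35000 nM.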

Compound 4, half-maximal inhibitory concentration: 24000 nM
Compound 4: the middle estimate sits 1.7-fold (0.23 log units) below what was measured, and the stated range covers the measured number.
By their numbers in this assay, from the lowest: compounds 1 and 2 (each within the scatter of the next); then compounds 3 and 4 (each within the scatter of the next).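

In this assay, acetyl in place of ethynyl on a saturated chain carbon bound to an amine nitrogen in a ring gives a 1.4-fold higher number from compound 3 to compound 4 (0.13 log units; within the scatter), so the added oxygen and hydrogen-bond acceptor leave no readable change at this position. 2-Oxopropyl in place of (2-phenylethenyl)carbonyl gives a 3.5-fold higher number from compound 1 to compound 4 (0.55 log units; beyond the scatter), in the same direction as propargyl in a 2.6-fold higher number from compound 1 to compound 3 (0.41 log units; beyond the scatter). Nothing available explains these steps.

The compounds shown leave open whether the difference rests on the phenyl ring or the carbon-carbon double bond of the (2-phenylethenyl)carbonyl group. A benzoyl or a 3-phenylpropanoyl group on that nitrogen would separate the two.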